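Phenyl in Place of Methyl on the Shared Core

The source may report more compounds than this note shows. Statements on the series, on what has been measured and on what is new or still open speak of the compounds shown alone.

Compound 1 `C/C(=N\Nc1nc(-c2ccccc2)cs1)c1sc(C)nc1C`: in a toxicity assay on HCT-116 cells (Homo sapiens) for cytotoxicity, read by MTT assay (on this read-out higher numbers stand for weaker inhibition of growth and lower numbers for stronger inhibition of growth), compound 1 gives > 100 ug/mL, a limit of the assay.
Compound 2 `C/C(=N\Nc1nc(-c2ccc(F)cc2)cs1)c1sc(C)nc1C`: in this assay compound 2 gives > 100 ug/mL, likewise a limit.
Compound 3 `COc1ccc(-c2csc(N/N=C(\C)c3sc(C)nc3C)n2)cc1`: in this assay compound 3 gives > 100 ug/mL, again a limit.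

Compound 2 stands where all three stand, at the limit of > 100 ug/mL in this assay, at which 3 of the 3 values shown sit. The steps a step that the two limits leave unreadable from compound 1 to compound 2, a step that the two limits leave unreadable from compound 1 to compound 3 and a step that the two limits leave unreadable from compound 2 to compound 3 therefore show neither size nor direction. Compound 4 `C/C(=N\Nc1nc(-c2ccc(F)cc2)cs1)c1sc(-c2ccccc2)nc1C` differs from compound 2 by phenyl in place of methyl on an aromatic carbon. Within the data shown here, none of the measured steps touches this position, so no measured step bears on the change. With every measured value at the limit, compound 4 is expected to sit near that limit too, with a wide range. The estimate for compound 4 is 120 ug/mL (from 40 ug/mL to 400 ug/mL). This means an expected step that the limit leaves unreadable from compound 2 to compound 4.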

Compound 4, concentration for 50% growth inhibition: > 100 ug/mL
Compound 4: no number, only a limit (the forecaster's own chance of this, stated with the estimate: 65%); the middle value lies beyond the limit too.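

No step can be read between compound 2 and compound 4, since both give only a limit in this assay. The compounds shown leave open whether any change to the shared core brings a readable value.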